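Halogenated Benzyl Ether Tested Against Three Flat Cytotoxicity Numbers

The compounds below may be only part of what the source reports. "The series", "measured", "known", "first", "only" and "open" are said of these compounds alone.

Compound 1 `c1ccc(CO/N=C2/C(c3c[nH]c4ccccc34)=Nc3ccccc32)cc1` gives 19500 nM in a functional assay on HepG2 cells (Homo sapiens) for cytotoxicity, read by MTT assay, with a stated time of 2 days (a lower number here means a stronger inhibitor, a higher number a weaker inhibitor), the second highest of three numbers, and its nearest neighbour compound 3 and furthest neighbour compound 2 both lie within the scatter of it. Compound 2 `Fc1ccc2c(c1)/C(=N\OCc1ccccc1)C(c1c[nH]c3ccc(F)cc13)=N2` gives 17300 nM in this assay, and compound 3 `Cc1ccc(CO/N=C2/C(c3c[nH]c4ccc(F)cc34)=Nc3ccc(F)cc32)cc1` gives 19600 nM there. The only single-point step among these three, a 1.1-fold higher number from compound 2 to compound 3 (0.05 log units; within the scatter), places a methyl in place of hydrogen on an aromatic carbon of the benzyl ring and stays within the scatter. Compound 4 `Fc1ccc(CO/N=C2/C(c3c[nH]c4ccccc34)=Nc3ccccc32)c(Cl)c1` differs from compound 1 by 2-chloro-4-fluorophenyl in place of phenyl on a saturated chain carbon bound to an oxygen on an unsaturated carbon. Going by the values given here, since the one comparable step also altered the benzyl ring without moving this assay beyond the scatter, compound 4 is expected to give about 18000 nM, between 8000 nM and 40000 nM. That estimate amounts to an expected step of a 1.1-fold lower number from compound 1 to compound 4 (0.03 log units; within the scatter).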

Compound 4, half-maximal inhibitory concentration: 25500 nM
Estimate against measurement, compound 4: 1.4-fold (0.15 log units) below, and the stated range covers the measured number.
By their numbers in this assay, from the lowest: compounds 2, 1, 3 and 4 (each within the scatter of the next).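

In this assay the change from benzyl to 2-chloro-4-fluorobenzyl, which brings in two halogens at once, gives a 1.3-fold higher number from compound 1 to compound 4 (0.12 log units; within the scatter) and so stays within the scatter. The earlier step had shown this only for a methyl on the benzyl ring, and now a chlorine and a fluorine on that ring also leave the number within the scatter. Nothing available explains this step. On these data alone, whether a carboxylic acid or an amine on this ring, or a longer chain in place of benzyl, would move the number beyond the scatter remains open.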